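Replacing the piperidin-1-yl group of compound 2

The compounds below may be only part of what the source reports. "The series", "measured", "known", "first", "only" and "open" are said of these compounds alone.

In a physicochemical assay for solubility, with a stated time of 18 h, at pH 7.4 (a higher number here means a more soluble compound, a lower number a less soluble compound), compound 2 (`O=[N+]([O-])c1ccc(C2=NOC(c3ccc(N4CCCCC4)cc3)C2)o1`) gives 1.1 ug/mL. Compound 1 (`O=C1COCCN1c1ccc(C2CC(c3ccc([N+](=O)[O-])o3)=NO2)cn1`) gives 21.9 ug/mL and compound 3 (`CN1CCN(c2ccc(C3CC(c4ccc([N+](=O)[O-])o4)=NO3)cn2)C(=O)C1`) gives 28.9 ug/mL. Compound 2 stands lowest of the three numbers, and its distance to each of the other two lies beyond the scatter. Compound 4 (`O=C1COCCN1c1ccc(C2CC(c3ccc([N+](=O)[O-])o3)=NO2)cc1`), not yet measured, has 3-oxomorpholin-4-yl in place of piperidin-1-yl on an aromatic carbon. Among the measured compounds shown here, the only measured step, a 1.3-fold higher number from compound 1 to compound 3 (0.12 log units; within the scatter) in size, involves a different exchange and bears on this one only indirectly. Compound 1 carries the same 3-oxomorpholin-4-yl on a different core and reads 21.9 ug/mL in support of a rise. The expected change is a 7.3-fold higher number from compound 2 to compound 4 (0.86 log units; beyond the scatter) and lies beyond the scatter. Expected for compound 4 is 8 ug/mL with a range from 2.5 ug/mL to 25 ug/mL as an estimate.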

Compound 4, solubility: 25.9 ug/mL
Compound 4: middle estimate off by 3.2-fold (0.51 log units), on the low side, outside the stated range (above it).
By their numbers in this assay, from the lowest: compound 2; then compounds 1, 4 and 3 (each within the scatter of the next).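

In this assay, among the compounds shown here, the exchange of piperidin-1-yl for 3-oxomorpholin-4-yl gives a 24-fold higher number from compound 2 to compound 4 (1.37 log units; beyond the scatter) as the only measured step at this position, and it lies beyond the scatter. It shows that this single change, on an aromatic carbon of a ring of carbon only, is enough on its own to lift the number well clear of the low reading of compound 2. No measurement shown here accounts for the size of the step. Going by these compounds, it remains open whether the carbonyl or the ring oxygen of 3-oxomorpholin-4-yl matters more. Morpholin-4-yl or 2-oxopiperidin-1-yl on the same carbon would separate the two.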